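The source may hold more compounds than are shown below. What is called first, only, known or untested is meant among the compounds shown, and "the series" means these compounds.

Series notes. Going by the values given here, compound 1 `Cn1cc(-c2cnc(NCc3c(F)ccc4c3CCO4)c3cn[nH]c(=O)c23)cn1` gives 2.7 in a physicochemical assay for lipophilicity, using the shake flask method, in phosphate buffer, measured as octanol-water partition, with a stated time of 30 min, at pH 7.4 (a lower number here means a more polar compound, a higher number a more lipophilic compound), the higher of the two numbers known so far. Among the compounds with values here, compound 2 `C[C@H]1CC(=O)N(c2cnc(NCc3c(F)ccc4c3CCO4)n3cnnc23)C1` gives 1.8 in this assay, a number lower by more than the usual scatter; the two structures differ in more than one place, so no single step is drawn between them. Compound 3 `CNC(=O)c1ncc(-c2cnc(NCc3c(F)ccc4c3CCO4)c3cn[nH]c(=O)c23)n1C` is not yet measured in this assay and differs from compound 1 in one place: 1-methyl-2-(methylcarbamoyl)-1H-imidazol-5-yl in place of 1-methyl-1H-pyrazol-4-yl on an aromatic carbon. A lower number is expected, as a step of a number 0.70 log units lower from compound 1 to compound 3 (beyond the scatter) in this assay, beyond the scatter. For compound 3 the estimate is 2, in the range 1.5 to 2.5.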

Compound 3, distribution coefficient: 2.5
Compound 3: middle estimate off by 0.50 log units, on the low side; the measured number falls inside the stated range.
By their numbers in this assay, from the lowest: compound 2; then compounds 3 and 1 (each within the scatter of the next).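

At this aromatic carbon, para to a large group, the swap to 1-methyl-2-(methylcarbamoyl)-1H-imidazol-5-yl gives a number 0.20 log units lower from compound 1 to compound 3 (within the scatter) in this assay. The entering group holds 1 hydrogen-bond donor where 1-methyl-1H-pyrazol-4-yl holds 0, yet this step stays within the scatter. No supporting measurement explains this result.

On these data alone, whether an amine or a carboxylic acid in place of the methylcarbamoyl would give a step beyond the scatter stays open. So does the size of the same swap on the core of compound 2.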